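The source may hold more compounds than are shown below. What is called first, only, known or untested is meant among the compounds shown, and "the series" means these compounds.

Compound 1 `CCn1ccnc1-c1cccc(Cl)c1CCc1cc(Br)ccc1OC` and compound 2 `COc1ccc(Br)cc1CCc1c(Cl)cccc1-c1nccn1CC1CC1` share one core and differ only at the saturated chain carbon bound to an aromatic nitrogen. In a functional assay on HEK293 cells (Homo sapiens), read by cAMP accumulation (on this read-out higher numbers stand for weaker inhibition and lower numbers for stronger inhibition), compound 1 gives 1800 nM, and compound 2 gives 1700 nM; the step of a 1.1-fold lower number from compound 1 to compound 2 (0.02 log units; within the scatter) leaves the two within the scatter of each other. Within the data shown here, compound 2 thus holds the lower of the two numbers, with compound 1 as its only neighbour and not separable from it.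

Compound 3 `COc1ccc(Br)cc1CCc1c(Cl)cccc1-c1ncc2n1CCC2` carries the change (a group of 8 heavy atoms (6 carbon, 2 nitrogen; one five-membered non-aromatic ring with 1 hetero atom, one five-membered aromatic ring with 2 hetero atoms) in place of a group of 9 heavy atoms (7 carbon, 2 nitrogen; one three-membered non-aromatic ring of carbon only, one five-membered aromatic ring with 2 hetero atoms), on an aromatic carbon). Among the measured compounds shown here, the only measured step that bears on it is the one from compound 1 to compound 2, which also reworks the substituent on that aromatic nitrogen and stayed within the scatter; no measured pair tests tying that substituent back into a five-membered non-aromatic ring. The expected step in this assay is therefore none beyond the scatter, no change at the digits printed from compound 2 to compound 3 (within the scatter). In this assay compound 3 is estimated at 1700 nM, with a range from 600 nM to 5000 nM.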

Compound 3, half-maximal inhibitory concentration: 710 nM
Estimate against measurement, compound 3: 2.4-fold (0.38 log units) above, within the range that was stated.
By their numbers in this assay, from the lowest: compound 3; then compounds 2 and 1 (each within the scatter of the next).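

Among these compounds, replacing the 1-(cyclopropylmethyl)-1H-imidazol-2-yl group with the group carrying a five-membered non-aromatic ring gives a 2.4-fold lower number from compound 2 to compound 3 (0.38 log units; beyond the scatter), the first change at this position in this assay to pass the scatter. The comparison with the open substituent of compound 1 points the same way, with a 2.5-fold lower number from compound 1 to compound 3 (0.40 log units; beyond the scatter), so compound 3 stands apart from both open substituents, though only modestly. Nothing measured here explains this gain.

The compounds shown leave open whether a six-membered non-aromatic ring in the same place, or a longer chain such as n-butyl on the aromatic nitrogen, would reach the same lower number. Also open, as far as these compounds go, is how an amine or a hydroxyl on the five-membered non-aromatic ring would read, and whether the step holds with another group in place of the chloro group.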